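One Fluorine Replaces a Larger Group

The source may report more compounds than this note shows. Statements on the series, on what has been measured and on what is new or still open speak of the compounds shown alone.

This piece concerns three small molecules tested in a functional assay on VCaP cells (Homo sapiens) for antiproliferative activity, read by propidium iodide staining, with a stated time of 96 h; on this read-out higher numbers stand for weaker inhibition and lower numbers for stronger inhibition. There, compound 1 (`CC(O)(CSc1cccc(S(F)(F)(F)(F)F)c1)C(=O)Nc1ccc([N+](=O)[O-])cc1C(F)(F)F`) gives 28800 nM, and compound 2 (`CC(O)(CSc1ccc(S(F)(F)(F)(F)F)cc1)C(=O)Nc1ccc(S(F)(F)(F)(F)F)cc1`) gives 28000 nM. These two values lie within the usual scatter of each other, so compound 2 stands level with compound 1, and neither can be ranked ahead.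

The next molecule is compound 3 (`CC(O)(CSc1ccc(F)cc1)C(=O)Nc1ccc(S(F)(F)(F)(F)F)cc1`), which is not yet measured. Going there from compound 2 makes one structural change: one fluorine atom in place of a group of 6 heavy atoms (5 fluorine, 1 sulfur; no ring), on an aromatic carbon. In plain words, one fluorine atom takes the place of a group of 6 heavy atoms on an aromatic carbon.

Among the measured compounds shown here, no two measured compounds differ in only one place, so the data give no direct guide to the size of such a step. Compound 1 and compound 2 differ in more than one place, yet compound 2 stays at 28000 nM, level with compound 1. A shift beyond the scatter is therefore not expected in this assay, though the uncertainty is wide. The expected step is a 1.1-fold higher number from compound 2 to compound 3 (0.03 log units; within the scatter). For compound 3, the estimated value is 30000 nM, with an expected range of 12000 nM to 70000 nM.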

Compound 3, half-maximal inhibitory concentration: 23000 nM
Estimate against measurement, compound 3: 1.3-fold (0.12 log units) above; the range from low to high includes it.
By their numbers in this assay, from the lowest: compounds 3, 2 and 1 (each within the scatter of the next).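

In this assay, placing one fluorine atom on this aromatic carbon in place of the group of 6 heavy atoms (5 fluorine, 1 sulfur) gives a 1.2-fold lower number from compound 2 to compound 3 (0.09 log units; within the scatter), the first direct reading of a change in a single place among these compounds. For this one pair, at this position para to a large group, the read-out does not separate the two substituents, even though one has far fewer heavy atoms than the other. The data shown contain no separate measurement that could explain this outcome.

The compounds shown leave open whether a different kind of group on this aromatic carbon, such as an amine, a carboxylic acid or a longer chain, would move the number beyond the usual scatter, or whether this position has little influence on the read-out whatever it carries. They also leave open whether the same exchange of groups would give a similar result on the core of compound 1, where other parts of the molecule differ.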